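Furan-2-yl in Place of Cyclopent-1-en-1-yl

A few compounds are considered here, and "the series" means these few. Any claim that something is new, unique, unknown or untested is made for them only; others in the source may bear on it.

In an ADME assay on microsomes from liver (Rattus norvegicus) for metabolic stability (a lower number here means that the compound disappears faster, a higher number that the compound lasts longer), compound 3 `Cn1nc2c(=O)n(CC3(O)CCN(Cc4ccc(C5=CCCC5)cc4Cl)CC3)cnc2c1-c1ccc(CN)cc1` gives 2.33 h. Compound 1 `Cn1nc2c(=O)n(CC3(O)CCN(Cc4ccc(-c5ccco5)cc4Cl)CC3)cnc2c1-c1ccc(CNCCO)cc1` gives 1.52 h, which lies within the scatter of the value for compound 3. Compound 2 `Cn1nc2c(=O)n(CC3(O)CCN(Cc4ccc(-c5ccco5)cc4Cl)CC3)cnc2c1-c1ccc(F)cc1` gives 0.75 h, and its gap to compound 3 lies beyond the scatter. Compound 3 therefore stands level with compound 1 and clear of compound 2.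

Compound 4 `Cn1nc2c(=O)n(CC3(O)CCN(Cc4ccc(-c5ccco5)cc4Cl)CC3)cnc2c1-c1ccc(CN)cc1` differs from compound 3 in a single group: furan-2-yl in place of cyclopent-1-en-1-yl on an aromatic carbon. For the measured compounds named here, no measured step makes this swap. Going by the values given here, the one step available, a 2.0-fold lower number from compound 1 to compound 2 (0.31 log units; beyond the scatter), is a different change: fluoro in place of ((2-hydroxyethyl)amino)methyl. Its size therefore gives no direct guide here.

The best clue is indirect. Like compound 4, compound 1 carries furan-2-yl and gives 1.52 h, although it also differs from compound 4 elsewhere. Compound 2 carries furan-2-yl as well, but its fluoro group makes its 0.75 h a weaker guide to compound 4. A small drop in this assay is thus the likeliest outcome, probably not beyond the scatter. The expected step is a 1.4-fold lower number from compound 3 to compound 4 (0.14 log units; within the scatter). For compound 4, the estimated half-life is 1.7 h, with an expected range from 0.9 h to 3.1 h.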

Compound 4, half-life: 2.37 h
Compound 4: middle estimate off by 1.4-fold (0.14 log units), on the low side; the measured number falls inside the stated range.
By their numbers in this assay, from the lowest: compound 2; then compounds 1, 3 and 4 (each within the scatter of the next).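

In this assay, for the compounds shown here, the swap itself can now be read for the first time: on this aromatic carbon, meta to the chloro group and para to a large group, furan-2-yl in place of cyclopent-1-en-1-yl gives a 1.0-fold higher number from compound 3 to compound 4 (0.01 log units; within the scatter), so the two five-membered rings cannot be told apart in this read-out when aminomethyl is present elsewhere in the molecule. With furan-2-yl kept in place, the new compound also separates two changes at that other site: aminomethyl in place of fluoro gives a 3.2-fold higher number from compound 2 to compound 4 (0.50 log units; beyond the scatter), whereas hydrogen in place of 2-hydroxyethyl on the amine nitrogen gives a 1.6-fold higher number from compound 1 to compound 4 (0.19 log units; within the scatter), so only the first of these steps stands clear of the usual variation between repeated measurements. Nothing available here accounts for either the match between the two rings or the gap between aminomethyl and fluoro.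

On these data alone, it remains open whether the two rings would still match with fluoro in place of aminomethyl. As far as these compounds go, it is also open whether a saturated cyclopentyl ring, a thiophen-2-yl ring or a phenyl ring at this position would give a half-life in the same range.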